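The source may report more compounds than this note shows. Statements on the series, on what has been measured and on what is new or still open speak of the compounds shown alone.

Compound 1 `Fc1cccc(-c2n[nH]cc2N2CCCNCC2)c1` gives 2540 nM in an assay on isolated protein for binding affinity to 5-hydroxytryptamine receptor 1D (Homo sapiens); a lower number here means a stronger inhibitor, a higher number a weaker inhibitor. Compound 2 `c1ccc(-c2n[nH]cc2N2CCCNCC2)cc1` sits at a limit of this assay, > 10000 nM. Within the data shown here, the only measured step is an at least 3.9-fold higher number from compound 1 to compound 2 (0.59 log units; beyond the scatter), a fluoro removed from the ring. Compound 3 `COc1ccccc1-c1n[nH]cc1N1CCNCC1` also stands at a limit of this assay, > 10000 nM, so no number is known for it. Two of the three values rest at the limit of > 10000 nM in this assay, at which 2 of the 3 values shown sit.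

Compound 4 `Fc1ccccc1-c1n[nH]cc1N1CCNCC1` carries the change (fluoro in place of methoxy on an aromatic carbon). The step from compound 1 to compound 2 concerns fluoro against hydrogen, not against methoxy, so it gives no direct measure here; fluoro did help there, which argues for a small gain at most. Compound 4 is therefore expected around 8000 nM, within 2500 nM to 30000 nM. The expected step of an at least 1.2-fold lower number from compound 3 to compound 4 (0.09 log units; that floor lies within the scatter) would leave compound 4 weak in this assay.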

Compound 4, inhibition constant: > 10000 nM
Compound 4 ended at the assay's limit (the forecaster's own chance of this, stated with the estimate: 50%); at least 1.2-fold (0.09 log units) between middle value and limit.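

Compound 3 and compound 4 both sit at a limit, so no step can be read for fluoro in place of methoxy: the limit of > 10000 nM in this assay, at which 3 of the 4 values shown sit. On these data alone, whether these two groups differ at all in this assay remains open.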